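Halogen swap at the fused ring of the oxindole-type core

A few compounds are considered here, and "the series" means these few. Any claim that something is new, unique, unknown or untested is made for them only; others in the source may bear on it.

Measured so far:
- compound 1 `COc1cc(Cn2cc(COc3cccc(/C=C4/C(=O)Nc5ccccc54)c3)nn2)cc(OC)c1`: 26700 nM
- compound 2 `O=C1Nc2ccc(Cl)cc2/C1=C/c1cccc(OCc2cn(Cc3ccccc3)nn2)c1`: > 50000 nM

In a functional assay on A549 cells (Homo sapiens) for inhibition, read by MTT assay, with a stated time of 48 h (on this read-out higher numbers stand for weaker inhibition and lower numbers for stronger inhibition), compound 1 gives 26700 nM. Compound 2 gives only a limit in this assay, > 50000 nM, and so no number. Its position is therefore (the limit of > 50000 nM in this assay, at which 1 of the 2 values shown sits); compound 2 stands at the weak end of what this pair shows, with no measured gap between the two compounds that could be sized.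

Compound 3 `O=C1Nc2ccc(Br)cc2/C1=C/c1cccc(OCc2cn(Cc3ccccc3)nn2)c1` is not yet measured. It differs from compound 2 in one place: bromo in place of chloro on an aromatic carbon. Within the data shown here, no step between measured compounds exists from which the effect of such a swap could be read. With chloro and bromo being single heavy atoms of the same kind of substituent, the expectation is a step from compound 2 to compound 3 of a step that the limit leaves unreadable from compound 2 to compound 3, which is none beyond the scatter, in this assay. Compound 3 is thus expected at about 60000 nM, within 25000 nM to 150000 nM, most likely again reported only as a limit.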

Compound 3, half-maximal inhibitory concentration: > 50000 nM
Compound 3: a limit, no number; the forecaster's own chance of this, stated with the estimate: 70%; the middle value lies beyond the limit too.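

Compound 3 gives only a limit in this assay, > 50000 nM. Compound 2 also gives only a limit there, so no step can be read between compound 2 and compound 3: the limit of > 50000 nM in this assay, at which 2 of the 3 values shown sit.

The compounds shown leave open how bromo and chloro on the shared core compare in this assay.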